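A few compounds are considered here, and "the series" means these few. Any claim that something is new, unique, unknown or untested is made for them only; others in the source may bear on it.

Compound 1 `CC(=O)Cn1cc(CNC(=O)c2cnc(Nc3ccc(C#N)cc3)cc2Oc2c(C)cc(C)cc2C)nn1`: 19400 nM
Compound 2 `Cc1cc(C)c(Oc2cc(Nc3ccc(C#N)cc3)ncc2C(=O)NCc2cn(Cc3cccc(C#N)c3)nn2)c(C)c1`: >= 129000 nM

In an ADME assay on MT4 cells (Homo sapiens) for cytotoxicity, read by MTT assay, with a stated time of 5 days (on this read-out higher numbers stand for lower toxicity in this test and lower numbers for higher toxicity in this test), compound 1 gives 19400 nM. For compound 2 this assay reports only a limit, >= 129000 nM. The single measured step, an at least 6.6-fold higher number from compound 1 to compound 2 (0.82 log units; beyond the scatter), thus ends at the limit (the limit of >= 129000 nM in this assay, at which 1 of the 2 values shown sits), so compound 2 stands at the top of the numbers shown, without a definite value of its own. Compound 3 `Cc1cc(C)c(Oc2cc(Nc3ccc(C#N)cc3)ncc2C(=O)NCc2cn(Cc3ccc([N+](=O)[O-])cc3)nn2)c(C)c1` differs from compound 2 by 4-nitrophenyl in place of 3-cyanophenyl on a saturated chain carbon bound to an aromatic nitrogen. Among the measured compounds shown here, no measured step covers this change; the step from compound 1 to compound 2 concerns a different group at the same place and only shows that the 3-cyanobenzyl group there reaches the limit. Compound 3 is therefore expected to remain close to that limit, with a number no higher from compound 2 to compound 3 (the limit leaves the size open), and its estimated value is 129000 nM, with a range from 50000 nM to 250000 nM.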

Compound 3, half-maximal cytotoxic concentration: >= 139000 nM
Compound 3 gave a limit, no number; the forecaster's own chance of this, stated with the estimate: 65%; at least 1.0-fold (0.03 log units) between middle value and limit.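

With the 4-nitrobenzyl group on the saturated chain carbon bound to an aromatic nitrogen, compound 3 also ends at a limit and gives no number in this assay: the limit of >= 139000 nM in this assay, at which 1 of the 3 values shown sits. The acetyl group of compound 1 now stands against two different aromatic replacements rather than one, with an at least 7.1-fold higher number from compound 1 to compound 3 (0.85 log units; beyond the scatter) alongside the earlier at least 6.6-fold higher number from compound 1 to compound 2 (0.82 log units; beyond the scatter). The step between the 3-cyanobenzyl and 4-nitrobenzyl groups cannot be read, since both values are limits, so these two groups cannot be ordered.

Going by these compounds, the true numbers of compound 2 and compound 3 remain open, as does whether a simple amine or a carboxylic acid at this place would stay near these limits or fall toward the value of compound 1. On these data alone, how a longer chain ending in a phenyl group would behave here is also open.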